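Methoxy step on the core of compound 1

The source may report more compounds than this note shows. Statements on the series, on what has been measured and on what is new or still open speak of the compounds shown alone.

- compound 1 `O=C1NC(=O)c2c1c1c3ccccc3ncc1c1[nH]c3ccccc3c21` gives 660 nM
- compound 2 `CN(C)CCCn1c2ccccc2c2c3c(c4c5ccccc5cnc4c21)C(=O)NC3=O` gives 370 nM

Both values come from a functional assay on NCI-H460 cells (Homo sapiens) for inhibition; a lower number here means a stronger inhibitor, a higher number a weaker inhibitor. Compound 1 and compound 2 lie within the scatter of each other, so compound 1 holds no separate place on these numbers, and the pair sets only a common level for the series.

Compound 3 `COc1ccc2c(c1)[nH]c1c3cnc4ccccc4c3c3c(c21)C(=O)NC3=O` is still unmeasured. The change methoxy in place of hydrogen on an aromatic carbon puts methoxy in place of hydrogen on an aromatic carbon of a six-membered aromatic ring of carbon only. Among the measured compounds shown here, no measured pair shows this change, so no direction can be drawn from the data. In this assay a step beyond the scatter is not expected, and compound 1 at 660 nM remains the only direct reference. The expected 1.3-fold lower number from compound 1 to compound 3 (0.12 log units; within the scatter) stays within the scatter. Compound 3 is estimated at 500 nM (expected range 150 nM to 1800 nM).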

Compound 3, half-maximal inhibitory concentration: 390 nM
Compound 3: middle estimate off by 1.3-fold (0.11 log units), on the high side, within the range that was stated.
By their numbers in this assay, from the lowest: compounds 2, 3 and 1 (each within the scatter of the next).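

In this assay, methoxy in place of hydrogen on an aromatic carbon of a six-membered aromatic ring of carbon only gives a 1.7-fold lower number from compound 1 to compound 3 (0.23 log units; within the scatter), a step within the scatter. Among the compounds shown here, this is the only one-place step so far, and it shows that on this carbon methoxy leaves the number at the common level set by the earlier compounds. With a single step, this holds for this position and this change alone, and no measurement bears on why the step is this size.

Going by these compounds, whether an amine, a carboxylic acid or a longer alkoxy chain on the same carbon would give a step beyond the scatter remains open. Also open, on these data alone, is how methoxy would read on the other carbons of this ring.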